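Working notes: fluoro in place of methyl

The source may report more compounds than this note shows. Statements on the series, on what has been measured and on what is new or still open speak of the compounds shown alone.

Measured in a functional assay on MCF7 cells (Homo sapiens) for inhibition, read by trypan blue exclusion, with a stated time of 3 days; on this read-out lower numbers stand for stronger inhibition and higher numbers for weaker inhibition
compound 1 `COc1cc(C(=O)c2cn(-c3ccccc3)cc2-c2cccc(C)c2)cc(OC)c1OC` gives 450 nM
compound 2 `COc1cc(C(=O)c2cn(-c3ccccc3)cc2-c2ccc(C)cc2)cc(OC)c1OC` gives 280 nM

Compound 2 at 280 nM sits within the scatter of compound 1, so the two cannot be ranked. Compound 3 `COc1cc(C(=O)c2cn(-c3ccccc3)cc2-c2ccc(F)cc2)cc(OC)c1OC` carries fluoro in place of methyl on an aromatic carbon, para to a large group: fluoro in place of methyl on an aromatic carbon (4-methylphenyl to 4-fluorophenyl). Among the compounds with values here, only one measured step bears on this change, a 1.6-fold lower number from compound 1 to compound 2 (0.21 log units; within the scatter) in which the methyl changes place, and it stays within the scatter. Within the data shown here, no measured pair exchanges methyl for fluoro, so the data point in no direction. In this assay the expected step is a 1.1-fold higher number from compound 2 to compound 3 (0.03 log units; within the scatter) and no shift beyond the scatter is expected. For compound 3 the estimated value is 300 nM with an expected range from 110 nM to 800 nM on this read-out.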

Compound 3, half-maximal inhibitory concentration: 78 nM
For compound 3 the middle estimate is 3.8-fold (0.59 log units) above the measured one; the measured number lies below the stated range.
By their numbers in this assay, from the lowest: compound 3; then compounds 2 and 1 (each within the scatter of the next).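

In this assay fluoro in place of methyl on an aromatic carbon, para to a large group, gives a step beyond the scatter (a 3.6-fold lower number from compound 2 to compound 3 (0.56 log units; beyond the scatter)), which the shift of the methyl in the earlier pair did not. The group at this place therefore changes the read-out, and 4-fluorophenyl also stands apart from 3-methylphenyl (a 5.8-fold lower number from compound 1 to compound 3 (0.76 log units; beyond the scatter)). No available evidence accounts for either step.

Still open, on these data alone, is whether the lower number belongs to fluoro itself or to the loss of methyl, a question that an unsubstituted phenyl, a chloro group or a methoxy group at this place could help separate. Also open, as far as these compounds go, is whether an amine there would fit the same series.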